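Dichloro analogue of a benzyl-substituted purine in a cytotoxicity test

The source may hold more compounds than are shown below. What is called first, only, known or untested is meant among the compounds shown, and "the series" means these compounds.

Measured compounds:
compound 1 `ClCc1cccc(Cn2cnc3ncnc(Cl)c32)c1` 7940 nM
compound 2 `ClCc1ccccc1Cn1cnc2ncnc(Cl)c21` 63100 nM
compound 3 `ClCc1cccc(Cn2cnc3nc(Cl)nc(Cl)c32)c1` 4780 nM

All three were tested in a functional assay on SNB-75 cells (Homo sapiens) for cytotoxicity, read by sulforhodamine B assay, with a stated time of 48 h; on this read-out lower numbers stand for higher toxicity in this test and higher numbers for lower toxicity in this test. Compound 1 gives 7940 nM there, compound 3 gives 4780 nM, and compound 2 gives 63100 nM, the highest of the three numbers, with the nearest of the others being compound 1.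

Compound 1 and compound 2 are built from the same atoms joined differently; how their two cores differ is not broken down here. Compound 3 arises from compound 1 by one change, (chloro in place of hydrogen on an aromatic carbon), and the step of a 1.7-fold lower number from compound 1 to compound 3 (0.22 log units; within the scatter).

Compound 4 `ClCc1ccccc1Cn1cnc2nc(Cl)nc(Cl)c21` has not yet been measured. It arises from compound 2 by chloro in place of hydrogen on an aromatic carbon, the same change that turns compound 1 into compound 3, made on the core of compound 2 instead. Among the compounds shown this change occurs only twice, so the one measured step is all there is to go on.

On that basis the step in this assay from compound 2 to compound 4 is expected to be about a 1.6-fold lower number from compound 2 to compound 4 (0.20 log units; within the scatter), close to the size seen because a 1.7-fold lower number from compound 1 to compound 3 (0.22 log units; within the scatter). Compound 4 is therefore estimated at 40000 nM, with a plausible range from 15000 nM to 110000 nM; the high starting number of compound 2 leaves open that the test reports only a limit.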

Compound 4, concentration lethal to 50% of the cells: > 100000 nM
Compound 4 ended at the assay's limit; the forecaster's own chance of this, stated with the estimate: 15%; middle value at least 2.5-fold (0.39 log units) from the limit.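

Compound 4 sits at a limit of the assay, so its value is not an exact number: the limit of > 100000 nM in this assay, at which 1 of the 4 values shown sits. Chloro in place of hydrogen on an aromatic carbon of the core of compound 2 gives an at least 1.5-fold higher number from compound 2 to compound 4 (0.19 log units; that floor lies within the scatter), and that figure is only a floor, so the true size of this step stays unknown. The pair therefore shows no clear drop in the number on either core, but it does not show that the change acts alike on both: the same change on two cores in this assay, a 1.7-fold lower number (0.22 log units; within the scatter) from compound 1 to compound 3 and an at least 1.5-fold higher number (0.19 log units; that floor lies within the scatter) from compound 2 to compound 4; the limit leaves it open whether they differ.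

The compounds shown leave open what an amine or a methoxy group would do at this same place on an aromatic carbon, since chloro is the only group that enters there. From the compounds shown here alone, with a single change on just two cores, it also stays open how large the step on the core of compound 2 really is and whether either step would be repeated on a third core.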